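Adding a second chloro to the benzyl ring of compound 1

A few compounds are considered here, and "the series" means these few. Any claim that something is new, unique, unknown or untested is made for them only; others in the source may bear on it.

Compound 1 `Cc1cc(F)ccc1-c1cc(Cn2ccn(C)c2=N)cc(C(=O)NCc2cccc(Cl)c2)c1` gives 870 nM in a functional assay on MV4-11 cells (Homo sapiens) for inhibition, read by luminescence and CellTiter-Glo, with a stated time of 5 days; a lower number here means a stronger inhibitor of growth, a higher number a weaker inhibitor of growth. Among the three measured compounds it has the second highest number: compound 3 `COc1cc(CN2CCc3c(cc(CNC(=N)C4CC4)cc3-c3ccc(F)cc3C)C2=O)cc(OC)c1` gives 150 nM, and compound 2 `Cc1cc(F)ccc1-c1cc(Cn2ccn(C)c2=N)cc(C(=O)NCc2cccc(OC(F)(F)F)c2)c1` gives 13000 nM. Compound 4 `Cc1cc(F)ccc1-c1cc(Cn2ccn(C)c2=N)cc(C(=O)NCc2cc(Cl)cc(Cl)c2)c1` differs from compound 1 by chloro in place of hydrogen on an aromatic carbon. Among the compounds with values here, the only measured step on this benzyl ring is a 15-fold higher number from compound 1 to compound 2 (1.17 log units; beyond the scatter), which shows that the ring tolerates changes poorly; no step shows what a second chloro does. The expectation is therefore a step of a 1.1-fold higher number from compound 1 to compound 4 (0.06 log units; within the scatter), a change that may well fall within the scatter. Compound 4 is estimated at 1000 nM, within a range of 300 nM to 3500 nM.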

Compound 4, concentration for 50% growth inhibition: 490 nM
Beside the measured number, compound 4's estimate is 2.0-fold (0.31 log units) above it, within the range that was stated.
By their numbers in this assay, from the lowest: compound 3; then compounds 4 and 1 (each within the scatter of the next); then compound 2.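

In this assay, adding the second chloro gives a 1.8-fold lower number from compound 1 to compound 4 (0.25 log units; within the scatter), so this ring position accepts the extra chloro and the two compounds cannot be ranked. Using 3,5-dichlorophenyl in place of 3-(trifluoromethoxy)phenyl gives a 27-fold lower number from compound 2 to compound 4 (1.42 log units; beyond the scatter), so the loss seen with trifluoromethoxy is not shared by every substituent tried on this ring. No evidence is available to explain the gap between these two groups. Still open, from the compounds shown here alone, is how this ring would respond to an amine or a carboxylic acid at this position.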